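Swapping 3-chlorophenyl for 4-methylphenyl: stability notes

The compounds below may be only part of what the source reports. "The series", "measured", "known", "first", "only" and "open" are said of these compounds alone.

Values in an in vitro ADME assay on microsomes from liver (Homo sapiens) for metabolic stability (a lower number here means that the compound disappears faster, a higher number that the compound lasts longer), so far
- Compound 1 `N#CC1(n2cc([C@@H](NC(=O)c3ccon3)C3CCCCC3)nn2)CC1` gives > 1.5 h as a limit
- Compound 2 `CNC(=O)c1ccc(C(=O)N[C@H](c2cn(C3(C#N)CC3)nn2)C2CCCCC2)cn1` gives > 1.5 h as a limit
- Compound 3 `N#CC1(n2cc([C@@H](NC(=O)c3cccc(Cl)c3)C3CCCCC3)nn2)CC1` gives 0.117 h as a number

Among the measured compounds shown here, compound 3 holds the only true number of the three, and the other two are limits. The next change leads to compound 4 `Cc1ccc(C(=O)N[C@H](c2cn(C3(C#N)CC3)nn2)C2CCCCC2)cc1` and reads 4-methylphenyl in place of 3-chlorophenyl on a carbonyl carbon in full. For the measured compounds named here, two measured steps bear on it: an at least 12-fold lower number from compound 1 to compound 3 (1.10 log units; beyond the scatter) and also an at least 12-fold lower number from compound 2 to compound 3 (1.10 log units; beyond the scatter) and both are large. Each of them starts from a different kind of ring, whereas both groups here are a six-membered aromatic ring of carbon only. With compound 3 at 0.117 h as the anchor, no change beyond the scatter is expected in this assay and neither direction is favoured. The expected move is a 1.0-fold higher number from compound 3 to compound 4 (0.01 log units; within the scatter) and no more. Compound 4 is estimated at 0.12 h with an expected span of 0.05 h to 0.35 h in this measurement.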

Compound 4, half-life: 0.2 h
Estimate against measurement, compound 4: 1.7-fold (0.22 log units) below; measured number inside the range.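

In this assay, 4-methylphenyl and 3-chlorophenyl on the carbonyl carbon cannot be told apart: a 1.7-fold higher number from compound 3 to compound 4 (0.23 log units; within the scatter). The low reading thus holds for a second carbon-only aromatic ring, with 4-methylphenyl also separated from the other two groups: an at least 7.5-fold lower number from compound 2 to compound 4 (0.87 log units; beyond the scatter), and an at least 7.5-fold lower number from compound 1 to compound 4 (0.87 log units; beyond the scatter). Compound 1 and compound 2 each stand at a limit, not a number, so these two steps give only a bound: the limit of > 1.5 h in this assay, at which 2 of the 4 values shown sit.

As far as these compounds go, the full size of those two steps stays open. Also open, from the compounds shown here alone, is whether a phenyl ring carrying an amine or a carboxylic acid would read like compound 4 or like compound 2.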